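Ethoxycarbonyl Removal and Cytotoxicity on Kidney Cells

The source may report more compounds than this note shows. Statements on the series, on what has been measured and on what is new or still open speak of the compounds shown alone.

Compound 1 `CC1(C)[C@H]2CC[C@]1(C)[C@H](OC(=O)CCN1CCNCC1)C2`, compound 2 `CCOC(=O)N1CCN(CCC(=O)O[C@@H]2C[C@@H]3CC[C@@]2(C)C3(C)C)CC1` and compound 3 `CCOC(=O)N1CCN(CC(=O)O[C@@H]2C[C@@H]3CC[C@@]2(C)C3(C)C)CC1` were tested in an ADME assay on MDCK cells (Canis lupus familiaris) for cytotoxicity, read by MTT assay, with a stated time of 48 h; on this read-out higher numbers stand for lower toxicity in this test and lower numbers for higher toxicity in this test. Compound 1 gives 12600 nM and compound 2 gives 150000 nM. In this assay compound 3 gives > 852000 nM, which is a limit of the assay rather than a number.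

Compound 1 and compound 2 differ in one place: hydrogen in place of ethoxycarbonyl on an amine nitrogen in a ring. That change brings a 12-fold lower number from compound 2 to compound 1 (1.08 log units; beyond the scatter), so the compound without the ethoxycarbonyl is the more toxic one here. The difference between the core of compound 2 and the core of compound 3 is not broken down here.

Compound 4 `CC1(C)[C@H]2CC[C@]1(C)[C@H](OC(=O)CN1CCNCC1)C2` has not been measured. It stands to compound 3 as compound 1 stands to compound 2, through the same change: hydrogen in place of ethoxycarbonyl on an amine nitrogen in a ring. From that parallel the step from compound 3 to compound 4 is expected to run in the same direction and of a similar size, giving an at least 12-fold lower number from compound 3 to compound 4 (1.08 log units; beyond the scatter), with the starting point uncertain because the limit of > 852000 nM in this assay, at which 1 of the 3 values shown sits, is what is known of compound 3. Compound 4 is therefore expected to give about 70000 nM, with a plausible span from 12000 nM to 500000 nM.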

Compound 4, half-maximal cytotoxic concentration: 51600 nM
Estimate against measurement, compound 4: 1.4-fold (0.13 log units) above, within the range that was stated.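

In this assay the swap of ethoxycarbonyl for hydrogen on the amine nitrogen in the ring gives an at least 16-fold lower number from compound 3 to compound 4 (1.21 log units; beyond the scatter) and so lowers the number on both cores, which means more toxicity in this test: the same change on two cores in this assay, a 12-fold lower number (1.08 log units; beyond the scatter) from compound 2 to compound 1 and an at least 16-fold lower number (1.21 log units; beyond the scatter) from compound 3 to compound 4; the limit leaves it open whether they differ. Compound 3 stands at a limit of the assay and not at a number: the limit of > 852000 nM in this assay, at which 1 of the 4 values shown sits. The direction of the change therefore carries over between these two pairs, but the data do not show whether its size is the same on both cores, and two pairs set no rule for any other core.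

The remaining step is a 4.1-fold higher number from compound 1 to compound 4 (0.61 log units; beyond the scatter) with piperazin-1-yl in place of (piperazin-1-yl)methyl on a saturated chain carbon bound to a carbonyl carbon, so the chain also moves the number when hydrogen sits on that nitrogen, though this rests on a single pair. Still open, on these data alone, is how a longer chain would read in this test, and whether an acetyl group or a methyl group on the same nitrogen would give numbers closer to those with ethoxycarbonyl or to those with hydrogen.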